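Swapping nitro for methyl in a weak fluoro compound

The source may hold more compounds than are shown below. What is called first, only, known or untested is meant among the compounds shown, and "the series" means these compounds.

Results in a functional assay on A2780 cells (Homo sapiens) for antiproliferative activity, read by MTT assay, with a stated time of 72 h; on this read-out higher numbers stand for weaker inhibition and lower numbers for stronger inhibition:
Compound 1 `O=C(c1cc2ccccc2o1)N1N=C(c2ccccc2)CC1c1ccc([N+](=O)[O-])cc1`: 4.87 ug/mL
Compound 2 `O=C(c1cc2ccccc2o1)N1N=C(c2ccc(F)cc2)CC1c1ccccc1`: 11.8 ug/mL
Compound 3 `O=C(c1cc2ccccc2o1)N1N=C(c2ccc(F)cc2)CC1c1ccc([N+](=O)[O-])cc1`: > 50 ug/mL, a limit of the assay and not a number

Compound 3 has no exact value, and it stands at the weak end of this small set: the limit of > 50 ug/mL in this assay, at which 1 of the 3 values shown sits. Compound 4 `Cc1ccc(C2CC(c3ccc(F)cc3)=NN2C(=O)c2cc3ccccc3o2)cc1` keeps the core of compound 3 but carries methyl in place of nitro on an aromatic carbon.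

For the measured compounds named here, two measured steps bear on this change. The closer one is an at least 4.2-fold higher number from compound 2 to compound 3 (0.62 log units; beyond the scatter), which came with nitro in place of hydrogen. The other is an at least 10-fold higher number from compound 1 to compound 3 (1.01 log units; beyond the scatter), which came with fluoro in place of hydrogen. Both end at a limit, so their true sizes could be larger. Together they show that compound 3 lost activity only where nitro and fluoro occur together.

Compound 4 also lacks the nitro, so compound 2, at 11.8 ug/mL, is the best guide, though methyl is not hydrogen. A lower number, of at least modest size, is therefore expected. The expected change is an at least 3.5-fold lower number from compound 3 to compound 4 (0.55 log units; beyond the scatter). For compound 4 the estimated value is 14 ug/mL, with an expected range of 4 ug/mL to 50 ug/mL.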

Compound 4, half-maximal inhibitory concentration: > 50 ug/mL
Compound 4 ended at the assay's limit; the forecaster's own chance of this, stated with the estimate: 20%; at least 3.5-fold (0.55 log units) between middle value and limit.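

With the fluoro kept, methyl in place of hydrogen gives an at least 4.2-fold higher number from compound 2 to compound 4 (0.62 log units; beyond the scatter), so the loss of activity seen with the fluoro present does not require a nitro group, and the earlier idea that it needs nitro and fluoro together no longer holds. The result for compound 4 is a limit of the assay and not a number, and it now sits with compound 3 at the weak end: the limit of > 50 ug/mL in this assay, at which 2 of the 4 values shown sit. The step between those two compounds cannot be read, so methyl and nitro cannot be ranked at this position, and among the three fluoro compounds only compound 2, with hydrogen there, gives an exact value.

As far as these compounds go, it remains open whether methyl would also cost activity without the fluoro, a question that matters because compound 1, which carries nitro without the fluoro, gives 4.87 ug/mL. Also open, from the compounds shown here alone, is whether any other group at this position, such as an amine or a carboxylic acid, could sit alongside the fluoro and still give a measurable value.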